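From a Cyclopentyl Sulfonamide to a Methylsulfonyl Pyrrolidine

This account rests on a few compounds, and the source may have more. Where it says the series, first, only, none or still open, it means among the compounds named here.

Of the compounds shown here, two sharing one core have been measured. Compound 1 `Brc1nn(-c2ccc3ncccc3c2)c2nc(N[C@@H]3CC[C@@H](c4ncc[nH]4)C3)ncc12` gives 21 nM in an assay on isolated protein for inhibition of eIF-2-alpha kinase GCN2 (Homo sapiens); on this read-out lower numbers stand for stronger inhibition and higher numbers for weaker inhibition. Within the data shown here, compound 2 `CNS(=O)(=O)[C@@H]1CC[C@@H](Nc2ncc3c(Br)nn(-c4ccc5ncccc5c4)c3n2)C1` gives 43 nM in this assay, the higher of the two numbers; the one step recorded, a 2.0-fold higher number from compound 1 to compound 2 (0.31 log units; beyond the scatter), exchanges the groups on a saturated ring carbon and leaves the rest untouched.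

Compound 3 `CS(=O)(=O)N1CC[C@@H](Nc2ncc3c(Br)nn(-c4ccc5ncccc5c4)c3n2)C1` is not yet measured. It differs from compound 2 by a group of 9 heavy atoms (5 carbon, 1 nitrogen, 2 oxygen, 1 sulfur; one five-membered non-aromatic ring with 1 hetero atom) in place of a group of 10 heavy atoms (6 carbon, 1 nitrogen, 2 oxygen, 1 sulfur; one five-membered non-aromatic ring of carbon only), on a nitrogen on an aromatic ring. Among the measured compounds shown here, no measured step concerns this kind of exchange: the only step known, from compound 1 to compound 2, alters what hangs from the saturated ring, not the ring itself, so it offers no direct guide. The size and direction of the change in this assay therefore rest on little evidence; a modest shift in either direction is as plausible as none beyond the scatter.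

Compound 3 is expected to give about 80 nM in this assay, within 25 nM to 300 nM, which corresponds to an estimated step of a 1.9-fold higher number from compound 2 to compound 3 (0.27 log units; within the scatter).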

Compound 3, half-maximal inhibitory concentration: 90 nM
Compound 3: middle estimate off by 1.1-fold (0.05 log units), on the low side; the measured number falls inside the stated range.
By their numbers in this assay, from the lowest: compound 1; then compound 2; then compound 3.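

In this assay, putting 1-(methylsulfonyl)pyrrolidin-3-yl on the nitrogen on an aromatic ring gives a 2.1-fold higher number from compound 2 to compound 3 (0.32 log units; beyond the scatter), so the number at this position answers to a change in the ring itself, whereas the earlier step had altered only what hangs from the ring. Measured against the 1H-imidazol-2-yl group of the first compound, the same exchange gives a 4.3-fold higher number from compound 1 to compound 3 (0.63 log units; beyond the scatter), which places the three groups in a clear order, with the lowest number for compound 1 and the highest for compound 3, each gap beyond the scatter. No measured evidence bears on why either step takes this size or direction.

The step to compound 3 exchanges the carbon ring for a ring with a hetero atom, and it also moves the sulfonyl group onto that ring nitrogen and leaves the new group without a hydrogen-bond donor, so these changes cannot be told apart here. Going by these compounds, it stays open whether an acetyl group, a free amine or the 1H-imidazol-2-yl group on that pyrrolidine would bring the number back down, or whether the pyrrolidine ring alone sets it.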